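Hydrogen for Fluoro: An Estimate for Compound 3

A few compounds are considered here, and "the series" means these few. Any claim that something is new, unique, unknown or untested is made for them only; others in the source may bear on it.

Measured compounds:
compound 1 `CSc1ccc(CSc2nc(-c3ccc(F)cc3)c(-c3ccncc3)[nH]2)cc1`: 670 nM
compound 2 `C[S+]([O-])c1ccc(CCSc2nc(-c3ccc(F)cc3)c(-c3ccncc3)[nH]2)cc1`: 500 nM

The study concerns a functional assay (Homo sapiens) for inhibition; a higher number here means a weaker inhibitor, a lower number a stronger inhibitor. Compound 1 `CSc1ccc(CSc2nc(-c3ccc(F)cc3)c(-c3ccncc3)[nH]2)cc1` gives 670 nM in this assay, the highest of the two numbers recorded, and its nearest neighbour is compound 2 `C[S+]([O-])c1ccc(CCSc2nc(-c3ccc(F)cc3)c(-c3ccncc3)[nH]2)cc1`, which gives 500 nM. For the measured compounds named here, the single measured step, a 1.3-fold lower number from compound 1 to compound 2 (0.13 log units; within the scatter), alters the group on a saturated chain carbon bound to a sulfur and lies within the scatter.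

Compound 3 `CSc1ccc(CSc2nc(-c3ccccc3)c(-c3ccncc3)[nH]2)cc1` has not yet been measured. It differs from compound 1 by hydrogen in place of fluoro on an aromatic carbon. Going by the values given here, this is a change at a different place from the one probed by the step from compound 1 to compound 2, so no measured step bears on it directly; the data offer no guide to the size or direction of the effect of losing a fluoro at this site. On that basis the expectation for compound 3 in this assay is a step of a 1.3-fold higher number from compound 1 to compound 3 (0.13 log units; within the scatter), that is, nothing clearly beyond the scatter, with wide uncertainty. The estimate for compound 3 is 900 nM, with a range from 350 nM to 2500 nM.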

Compound 3, half-maximal inhibitory concentration: 72500 nM
The estimate for compound 3 lay 81-fold (1.91 log units) below the measured number; measured number outside the range, above it.
By their numbers in this assay, from the lowest: compounds 2 and 1 (each within the scatter of the next); then compound 3.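

The move from 4-fluorophenyl to phenyl gives a 110-fold higher number from compound 1 to compound 3 (2.03 log units; beyond the scatter) in this assay, whereas the change on the saturated chain carbon gave a 1.3-fold lower number from compound 1 to compound 2 (0.13 log units; within the scatter). For the compounds shown here, of the two places varied in these compounds, the aromatic carbon para to a large group is therefore the only one where the number moves beyond the scatter. The change there is small in count, a single fluorine atom giving way to hydrogen, yet nothing at hand bears on why the number rises so far.

Going by these compounds, whether another group on that aromatic carbon, such as chloro, methyl or methoxy, would keep the number close to that of compound 1 or leave it close to that of compound 3 remains open. On these data alone, it is also open whether replacing the fluoro with hydrogen in compound 2 would produce a step of similar size, as this step is read on the background of compound 1 alone.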